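Removing the sulfamoyl: from compound 3 to compound 4

The source may hold more compounds than are shown below. What is called first, only, known or untested is meant among the compounds shown, and "the series" means these compounds.

Measured compounds:
compound 1, `N#CC1CN1C(=O)Nc1ccc(Cl)cc1Cl`: 207000 nM
compound 2, `N#CC1CN1C(=O)Nc1ccc(Cl)c(Cl)c1`: 2600 nM
compound 3, `N#CC1CN1C(=O)Nc1ccc(S(N)(=O)=O)cc1`: > 38000 nM

The three compounds share one core and differ only in the aromatic substituents. In a functional assay on L1210 cells (Mus musculus) for inhibition, read by MTT assay (a lower number here means a stronger inhibitor, a higher number a weaker inhibitor), compound 1 gives 207000 nM and compound 2 gives 2600 nM. For compound 3 only a limit is reported, > 38000 nM; this is the limit of > 38000 nM in this assay, at which 1 of the 3 values shown sits, not a number, so compound 3 stands at the weak end of what is shown. Compound 4, `N#CC1CN1C(=O)Nc1ccccc1`, has not been measured. It differs from compound 3 by hydrogen in place of sulfamoyl on an aromatic carbon. Among the compounds with values here, no measured step matches this change, so the expected step of an at least 1.9-fold lower number from compound 3 to compound 4 (0.27 log units; that floor lies within the scatter) is a guess toward a somewhat stronger inhibitor. Compound 4 is estimated at 20000 nM, between 3000 nM and 150000 nM.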

Compound 4, half-maximal inhibitory concentration: 1200 nM
Beside the measured number, compound 4's estimate is 17-fold (1.22 log units) above it; measured number outside the range, below it.
By their numbers in this assay, from the lowest: compound 4; then compound 2; then compound 1.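

Replacing sulfamoyl with hydrogen on this aromatic carbon gives an at least 31-fold lower number from compound 3 to compound 4 (1.50 log units; beyond the scatter) in this assay, the first step the series offers at this position. The size of that step is only a floor, because the value of compound 3 is a limit and not a number: the limit of > 38000 nM in this assay, at which 1 of the 4 values shown sits. Compound 4, which carries no substituent on its aromatic ring, gives 1200 nM, so no substituent is needed at this place for a value this low.

The compounds shown leave open whether a single chlorine, an amine or a carboxylic acid at this position would keep the value of compound 4 or lose it, as sulfamoyl does.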